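A few compounds are considered here, and "the series" means these few. Any claim that something is new, unique, unknown or untested is made for them only; others in the source may bear on it.

Compound 1 `Cc1cc(=O)c(O)c(Cc2ccccc2)o1`: > 50000 nM, a limit
Compound 2 `Cc1cc(=O)c(O)c(Cc2ccc(C(F)(F)F)cc2)o1`: 24400 nM
Compound 3 `Cc1cc(=O)c(O)c(Cc2ccc(OCc3ccccc3)cc2)o1`: > 50000 nM, a limit

All three compounds were tested in a functional assay on HT-1080 cells (Homo sapiens) for antiproliferative activity, read by MTT assay; a lower number here means a stronger inhibitor, a higher number a weaker inhibitor. Compound 3 gives > 50000 nM, which is a limit and not a number. It stands at the limit of > 50000 nM in this assay, at which 2 of the 3 values shown sit.

Compound 4 `Cc1cc(=O)c(O)c(C(c2ccc(OCc3ccccc3)cc2)c2oc(C)cc(=O)c2O)o1` changes compound 3 at one place: a group of 9 heavy atoms (6 carbon, 3 oxygen; one six-membered aromatic ring with 1 hetero atom) in place of a hydrogen atom, on a saturated chain carbon bound to two aromatic carbons. The added group is a large one, and compound 4 has not yet been measured.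

The measured steps all change a group on an aromatic carbon. Trifluoromethyl in place of hydrogen gave an at least 2.0-fold lower number from compound 1 to compound 2 (0.31 log units; beyond the scatter). Benzyloxy in place of trifluoromethyl gave an at least 2.0-fold higher number from compound 2 to compound 3 (0.31 log units; beyond the scatter). Benzyloxy in place of hydrogen gave a step that the two limits leave unreadable from compound 1 to compound 3. None of them touches the saturated chain carbon, so they offer only a loose guide to the size of this new step.

Only compound 2 reaches a number, at 24400 nM, so a reading in that region is the most that these data support. A modest fall in the number is therefore expected, and compound 4 may well stay at the limit. The expected change is an at least 1.5-fold lower number from compound 3 to compound 4 (0.19 log units; that floor lies within the scatter). For compound 4 the estimate is 32000 nM. The expected range runs from 10000 nM to 50000 nM.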

Compound 4, half-maximal inhibitory concentration: 1430 nM
Compound 4: the middle estimate sits 22-fold (1.35 log units) above what was measured; the measured number lies below the stated range.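

For the compounds shown here, the saturated chain carbon bound to two aromatic carbons is untouched in the earlier compounds, and this result shows that a change there can move the number much: in this assay, the group of 9 heavy atoms in place of a hydrogen atom gives an at least 34-fold lower number from compound 3 to compound 4 (1.54 log units; beyond the scatter). The entering group repeats the shared core, and the benzyloxy group stays in place, so benzyloxy on the aromatic carbon does not by itself hold a compound of this series at the limit. Compound 3 gives > 50000 nM, which is a limit and not a number, so the step is only a floor, because its starting point sits at the edge of what the assay reports: the limit of > 50000 nM in this assay, at which 2 of the 4 values shown sit.

The compounds shown leave open whether the whole added group is needed, or whether a methyl group or an amine on the same saturated chain carbon would shift the number too. They also leave open whether the same group brings a step of similar size when the benzyloxy is replaced by hydrogen or trifluoromethyl, as in compound 1 and compound 2.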